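Removing the Fluoro Group from Compound 2

The source may hold more compounds than are shown below. What is called first, only, known or untested is meant among the compounds shown, and "the series" means these compounds.

- compound 1 `O=C(N/N=C/c1cccc(Br)c1)Nc1ccc(Oc2ccnc3[nH]ccc23)c(F)c1`: 660 nM
- compound 2 `O=C(N/N=C/c1ccc([N+](=O)[O-])cc1)Nc1ccc(Oc2ccnc3[nH]ccc23)c(F)c1`: 3030 nM
- compound 3 `O=C(N/N=C/c1ccc(F)cc1Cl)Nc1ccc(Oc2ccnc3[nH]ccc23)c(F)c1`: 1110 nM

In a functional assay on HepG2 cells (Homo sapiens) for antiproliferative activity, read by MTT assay, with a stated time of 72 h (a lower number here means a stronger inhibitor, a higher number a weaker inhibitor), compound 2 gives 3030 nM, the highest of the three numbers. Compound 4 `O=C(N/N=C/c1ccc([N+](=O)[O-])cc1)Nc1ccc(Oc2ccnc3[nH]ccc23)cc1` differs from it by hydrogen in place of fluoro on an aromatic carbon. Going by the values given here, no measured step covers this change. The available steps, a 4.6-fold higher number from compound 1 to compound 2 (0.66 log units; beyond the scatter), a 2.7-fold lower number from compound 2 to compound 3 (0.44 log units; beyond the scatter) and a 1.7-fold higher number from compound 1 to compound 3 (0.23 log units; within the scatter), all alter the aryl group on the carbon with a double bond to nitrogen, so they bear on it only indirectly and mainly widen the range. The expected change in this assay is a 1.1-fold lower number from compound 2 to compound 4 (0.03 log units; within the scatter), with no shift in either direction expected beyond the scatter. For compound 4 the estimated value is 2800 nM, with an expected range of 1200 nM to 6500 nM.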

Compound 4, half-maximal inhibitory concentration: 4620 nM
Beside the measured number, compound 4's estimate is 1.7-fold (0.22 log units) below it; measured number inside the range.
By their numbers in this assay, from the lowest: compounds 1 and 3 (each within the scatter of the next); then compounds 2 and 4 (each within the scatter of the next).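

In this assay the change to hydrogen in place of fluoro on an aromatic carbon gives a 1.5-fold higher number from compound 2 to compound 4 (0.18 log units; within the scatter), the only step shown that alters the shared core rather than the aryl group on the carbon with a double bond to nitrogen. With the 4-nitrophenyl group held constant, this position therefore tolerates loss of the fluoro group without a change beyond the scatter. No supporting data bear on this result.

On these data alone, whether the same holds with the 3-bromophenyl or 2-chloro-4-fluorophenyl group remains open. So does the outcome with chloro, methyl or methoxy at this position.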